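The source may report more compounds than this note shows. Statements on the series, on what has been measured and on what is new or still open speak of the compounds shown alone.

Of the compounds shown here, three have so far been measured in a functional assay on OVCAR-3 cells (Homo sapiens) for cytotoxicity, read by sulforhodamine B assay, with a stated time of 48 h; on this read-out lower numbers stand for stronger inhibition of growth and higher numbers for weaker inhibition of growth. Compound 1 `ClCc1ccccc1Cn1cnc2c(Cl)nc(Cl)nc21` gives 210 nM. Compound 2 `ClCc1ccccc1Cn1cnc2c(Cl)ncnc21` gives 1410 nM in this assay, and compound 3 `ClCc1cccc(Cn2cnc3c(Cl)ncnc32)c1` gives 1620 nM. Compound 1 and compound 2 differ in one place only, (chloro in place of hydrogen on an aromatic carbon), and that change brought a 6.7-fold lower number from compound 2 to compound 1 (0.83 log units; beyond the scatter). Compound 2 and compound 3 are built from the same atoms joined differently; the difference between the two cores is not broken down here, and their values in this assay lie within the scatter of each other.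

Compound 4 `ClCc1cccc(Cn2cnc3c(Cl)nc(Cl)nc32)c1` has not yet been measured in this assay. It stands to compound 3 as compound 1 stands to compound 2: the change is chloro in place of hydrogen on an aromatic carbon, the same change at the same place as before. Because a 6.7-fold lower number from compound 2 to compound 1 (0.83 log units; beyond the scatter) was seen, a step of about the same size is expected here, a 6.5-fold lower number from compound 3 to compound 4 (0.81 log units; beyond the scatter) in this assay. Compound 4 is therefore expected to give about 250 nM in this assay, with a likely range from 110 nM to 600 nM.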

Compound 4, concentration for 50% growth inhibition: 1580 nM
For compound 4 the middle estimate is 6.3-fold (0.80 log units) below the measured one; the measured number lies above the stated range.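

In this assay, chloro in place of hydrogen on the aromatic carbon between two ring nitrogen atoms did not repeat its earlier effect on the second core, the new step being a 1.0-fold lower number from compound 3 to compound 4 (0.01 log units; within the scatter). Set beside the earlier step, the two results differ by more than the usual scatter of two such steps: the same change on two cores in this assay, a 6.7-fold lower number (0.83 log units; beyond the scatter) from compound 2 to compound 1 and a 1.0-fold lower number (0.01 log units; within the scatter) from compound 3 to compound 4, 6.5-fold (0.82 log units) apart, beyond the scatter of two such steps This shows that, within these two pairs, the size of the step seen on the core of compound 2 could not be carried over to the core of compound 3, but it does not show what separates the two cores or how the same change would behave on any further core.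

The compounds shown leave open whether an amine or a methoxy group at that carbon would give a step like either of the two, on either core. They also leave open whether a bromo group there would show the same gap between the cores.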